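The source may report more compounds than this note shows. Statements on the series, on what has been measured and on what is new or still open speak of the compounds shown alone.

Measured compounds in a functional assay on HEK293 cells for agonist activity at Free fatty acid receptor 1 (Homo sapiens), read by calcium flux; on this read-out lower numbers stand for an effect already at smaller amounts and higher numbers for an effect only at larger amounts of compound:
compound 1, `CCCOc1ccc(C(CC(=O)O)c2ccccc2)cc1`, 4.8 uM;
compound 2, `CCCCCOc1ccc(C(CC(=O)O)c2ccccc2)cc1`, 2.97 uM;
compound 3, `CC(C)CCOc1ccc(C(CC(=O)O)c2ccccc2)cc1`, 1.86 uM.

Compound 2 gives the second highest of the three numbers: compound 3 lies nearest, and compound 1 furthest, each within the scatter of it. Compound 4, `CCC(C)COc1ccc(C(CC(=O)O)c2ccccc2)cc1`, has not yet been measured; it differs from compound 2 by sec-butyl in place of butyl on a saturated chain carbon bound to an oxygen on an aromatic ring. The step that bears most on this is the branching of the same chain from compound 2 to compound 3, a 1.6-fold lower number from compound 2 to compound 3 (0.20 log units; within the scatter). The lengthening step a 1.6-fold lower number from compound 1 to compound 2 (0.21 log units; within the scatter) also stayed within the scatter. For compound 4 a step of a 1.2-fold lower number from compound 2 to compound 4 (0.07 log units; within the scatter) is therefore expected, not beyond the scatter. Compound 4 is estimated at 2.5 uM, within 1.2 uM to 5.5 uM.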

Compound 4, concentration for half-maximal effect: 0.3 uM
Estimate against measurement, compound 4: 8.3-fold (0.92 log units) above, outside the stated range (below it).
By their numbers in this assay, from the lowest: compound 4; then compounds 3, 2 and 1 (each within the scatter of the next, the first and the last beyond it).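

Branching at this place matters more than chain size. In this assay, pentyloxy and 2-methylbutoxy have the same atoms, yet that rearrangement gives a step well beyond the scatter (a 9.9-fold lower number from compound 2 to compound 4 (1.00 log units; beyond the scatter)), and sec-butyl in place of isobutyl, a shift of the branch along the chain, also counts (a 6.2-fold lower number from compound 3 to compound 4 (0.79 log units; beyond the scatter)). Against the shorter chain the step is larger still (a 16-fold lower number from compound 1 to compound 4 (1.20 log units; beyond the scatter)), and no measurement shown offers an explanation for these steps. As far as these compounds go, whether a longer chain such as hexyloxy, or a cyclopropyl group at the branch, would keep so low a number remains open.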